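Adding methoxy to the acetamido group of compound 3

The source may report more compounds than this note shows. Statements on the series, on what has been measured and on what is new or still open speak of the compounds shown alone.

Three compounds have values in a functional assay on HeLa cells (Homo sapiens) for antiproliferative activity, read by MTT assay, with a stated time of 48 h; on this read-out higher numbers stand for weaker inhibition and lower numbers for stronger inhibition. Compound 3 `C=C(c1cc(OC)c(OC)c(OC)c1)c1ccc(OC)c(O)c1NC(C)=O` gives 90 nM. Compound 2 `COc1ccc(C(=O)c2cc(OC)c(OC)c(OC)c2)c(NC(=O)CO)c1` gives 70 nM, within the scatter of compound 3. Compound 1 `COc1ccc(C(=O)c2ccc(OC)c3c2C=CC(C)(C)O3)c(NC(=O)CBr)c1` gives 3680 nM, a much higher number and beyond the scatter of the other two. Compound 3 therefore belongs to the stronger pair of this small set.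

The unmeasured compound 4 `C=C(c1cc(OC)c(OC)c(OC)c1)c1ccc(OC)c(O)c1NC(=O)COC` differs from compound 3 in one place: methoxy in place of hydrogen on a saturated chain carbon bound to a carbonyl carbon. Methoxy stands in place of hydrogen on a saturated chain carbon bound to a carbonyl carbon, turning acetamido into ((methoxymethyl)carbonyl)amino.

Going by the values given here, no measured pair isolates this change, so the evidence is indirect. Compound 2 carries a hydroxyl on such a carbon and still gives 70 nM, although its core differs from that of compound 3. Compound 1 carries bromine on such a carbon and gives 3680 nM, but its core differs too, so it offers a poor guide.

In this assay, no step beyond the scatter is expected, with at most a slight lean towards a higher number. The estimated step of a 1.2-fold higher number from compound 3 to compound 4 (0.09 log units; within the scatter) is expected to stay within the scatter. For compound 4 the estimated value is 110 nM, with an expected range from 40 nM to 320 nM.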

Compound 4, half-maximal inhibitory concentration: 330 nM
Compound 4: middle estimate off by 3.0-fold (0.48 log units), on the low side; the whole stated range lies below it.
By their numbers in this assay, from the lowest: compounds 2 and 3 (each within the scatter of the next); then compound 4; then compound 1.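

In this assay, methoxy in place of hydrogen on a saturated chain carbon bound to a carbonyl carbon gives a 3.7-fold higher number from compound 3 to compound 4 (0.56 log units; beyond the scatter), so this position does not accept the change without a loss. Going by these compounds alone, this is the only step that isolates a change at this position; compound 1 and compound 2 also carry a substituent on such a carbon, but their cores differ, so neither could show the effect of a substituent there. On the shared core of compound 3 and compound 4, acetamido therefore gives stronger inhibition than ((methoxymethyl)carbonyl)amino, but no measurement shown bears on the reason for the rise in the number.

A single substituent on one core cannot show whether any group on this carbon raises the number or whether the step is specific to methoxy. Hydroxyl, fluorine or a dimethylamino group on this carbon of the core of compound 3, or a longer chain such as ethyl or propyl in place of the methyl of acetamido, would help separate these possibilities.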